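A few compounds are considered here, and "the series" means these few. Any claim that something is new, unique, unknown or untested is made for them only; others in the source may bear on it.

Compound 1 `O=C1C=C(Nc2ccc(OC(F)(F)F)cc2)C(=O)c2scnc21` gives > 100 ug/mL in a functional assay on HepG2 cells (Homo sapiens) for cytotoxicity, read by MTT assay (a lower number here means a stronger inhibitor, a higher number a weaker inhibitor), which is a limit of the assay rather than a number.
Compound 2 `CCCCCCc1ccc(NC2=CC(=O)c3sc(C)nc3C2=O)cc1` gives 22 ug/mL in this assay.

In this assay, among the measured compounds shown here, compound 1 stands at the limit of > 100 ug/mL in this assay, at which 1 of the 2 values shown sits, so only a limit is known for it, and no measured step connects it to compound 3 `O=C1C=C(Nc2ccccc2)C(=O)c2scnc21`. Compound 3 differs from compound 1 by hydrogen in place of trifluoromethoxy on an aromatic carbon. Starting from compound 1, the step is expected to be small, a number no higher from compound 1 to compound 3 (the limit leaves the size open), none beyond the scatter. Compound 3 is therefore estimated at 100 ug/mL, between 30 ug/mL and 300 ug/mL, and may well again be reported only as a limit.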

Compound 3, half-maximal inhibitory concentration: 14.7 ug/mL
For compound 3 the middle estimate is 6.8-fold (0.83 log units) above the measured one; measured number outside the range, below it.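

In this assay, this aromatic carbon is not a neutral place: hydrogen in place of trifluoromethoxy gives an at least 6.8-fold lower number from compound 1 to compound 3 (0.83 log units; beyond the scatter). Compound 3, with no substituent there, thus gives a measured number, whereas compound 1 gives only a limit of the assay. The full size of the step stays unknown, as one end of it is that limit: the limit of > 100 ug/mL in this assay, at which 1 of the 3 values shown sits.

As far as these compounds go, whether fluorine, a methoxy group or an amine on this carbon would give a number nearer that of compound 3 remains open. Also open, from the compounds shown here alone, is whether the same change would have a similar effect on the core of compound 2.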